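Working notes: chain length and amine in a short series

The source may report more compounds than this note shows. Statements on the series, on what has been measured and on what is new or still open speak of the compounds shown alone.

Measured so far in a functional assay on MDA-MB-231 cells (Homo sapiens) for inhibition, read by MTT assay, with stated times of 18 h and 4 h; on this read-out lower numbers stand for stronger inhibition and higher numbers for weaker inhibition:
compound 1 `CCCCCCCCCCOP(=O)(O)OCCSC(=S)N1CCCC1` gives 67000 nM
compound 2 `CCCCCCOP(=O)(O)OCCSC(=S)N1CCN(C)CC1` gives 73000 nM
compound 3 `CCCCCCCCCCOP(=O)(O)OCCSC(=S)N1CCN(C)CC1` gives 29000 nM

Compound 3 stands lowest of the three numbers in this assay, and both steps toward it lie beyond the scatter: a 2.3-fold lower number from compound 1 to compound 3 (0.36 log units; beyond the scatter), and a 2.5-fold lower number from compound 2 to compound 3 (0.40 log units; beyond the scatter). On these numbers compound 3 is the most potent of the measured set.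

Compound 4 `CCCCCCCCOP(=O)(O)OCCSC(=S)N1CCN(C)CC1` is not yet measured. Relative to compound 3 the change is hydrogen in place of ethyl on a saturated chain carbon, eight bonds along the chain from an oxygen on an unsaturated carbon. Going by the values given here, only one measured step speaks to the chain: a 2.5-fold lower number from compound 2 to compound 3 (0.40 log units; beyond the scatter), where lengthening the chain gave a modest gain. Among the compounds with values here, compound 4 sits between compound 2 and compound 3 in chain length, so a partial reversal of that gain is the natural expectation, with no other measured pair bearing on the same position. Within the data shown here, no step tells whether the effect of chain length is even, so the size is uncertain.

Compound 4 is therefore expected to give 45000 nM in this assay, with a range of 25000 nM to 80000 nM. This estimate means a 1.6-fold higher number from compound 3 to compound 4 (0.19 log units; within the scatter), a step expected to be modest, near the scatter.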

Compound 4, half-maximal inhibitory concentration: 58500 nM
Estimate against measurement, compound 4: 1.3-fold (0.11 log units) below; the measured number falls inside the stated range.
By their numbers in this assay, from the lowest: compounds 3, 4, 1 and 2 (each within the scatter of the next, the first and the last beyond it).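

In this assay, the change to hydrogen in place of ethyl, eight bonds along the chain from an oxygen on an unsaturated carbon, gives a 2.0-fold higher number from compound 3 to compound 4 (0.30 log units; within the scatter) and so cannot be told from no change, while ethyl in place of hydrogen, six bonds along the chain from that oxygen, gives a 1.2-fold lower number from compound 2 to compound 4 (0.10 log units; within the scatter) and is equally unresolved. The earlier butyl in place of hydrogen step, a 2.5-fold lower number from compound 2 to compound 3 (0.40 log units; beyond the scatter) in this assay, therefore stands as a difference only across the whole change: compound 4 cannot be set apart from compound 2 or compound 3, and the data do not assign that difference to either ethyl step. No supporting measurement bears on the reason for this behaviour of the chain.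

Still open, from the compounds shown here alone, is whether a longer chain than that of compound 3 would carry the number further down, or whether a carboxylic acid at the end of the chain would be tolerated. Also open is whether the same chain changes read the same way with pyrrolidin-1-yl on the thiocarbonyl carbon, where only compound 1 is shown.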